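Dropping One Chloro Group from the Triazene of Compound 3

A few compounds are considered here, and "the series" means these few. Any claim that something is new, unique, unknown or untested is made for them only; others in the source may bear on it.

Compound 1 `FC(F)(F)c1cccc(/N=N/N2CCCC2)c1` gives > 100000 nM in an ADME assay on MT4 cells (Homo sapiens) for cytotoxicity, read by MTT assay, with a stated time of 96 h (a higher number here means that more compound is tolerated, a lower number that less compound is tolerated), a limit of the assay rather than a number.
Compound 2 `c1ccc(/N=N/N2CCCC2)cc1` gives > 100000 nM, also a limit.
Compound 3 `Clc1ccc(/N=N/N2CCCC2)cc1Cl` gives 75000 nM.

Compound 3 thus holds the only number shown; the other two values are limits. Among the compounds with values here, the single measured step, a step that the two limits leave unreadable from compound 1 to compound 2, cannot be sized because the limit of > 100000 nM in this assay, at which 2 of the 3 values shown sit, hides its end.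

Compound 4 `Clc1cccc(/N=N/N2CCCC2)c1` changes compound 3 in one place: hydrogen in place of chloro on an aromatic carbon. Within the data shown here, no measured step tells how much tolerance such a change brings, so the expectation leans on compound 2 sitting at a limit. The expected step is a 1.3-fold higher number from compound 3 to compound 4 (0.12 log units; within the scatter). Compound 4 is therefore estimated at 100000 nM, within 50000 nM to 300000 nM, quite possibly reported only as a limit.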

Compound 4, half-maximal cytotoxic concentration: > 100000 nM
Compound 4 gave a limit, no number (the forecaster's own chance of this, stated with the estimate: 55%); the middle value sits exactly at the limit.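

In this assay, hydrogen in place of the chloro group para to a group of 7 heavy atoms gives an at least 1.3-fold higher number from compound 3 to compound 4 (0.12 log units; that floor lies within the scatter). Within the data shown here, this floor alone shows no real gain in tolerance, but it is the first step here that starts from a measured number, and it shows that compound 4, with one chloro group left, also reaches a limit. The steps from compound 1 and compound 2 to compound 4 cannot be read, because both ends sit at a limit: the limit of > 100000 nM in this assay, at which 3 of the 4 values shown sit.

As far as these compounds go, the true size of the step from compound 3 stays open. So does the effect of a methoxy group or an amine at this position.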